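Pyridinyl to Phenyl on the Cyclopropyl Amide

This account rests on a few compounds, and the source may have more. Where it says the series, first, only, none or still open, it means among the compounds named here.

Measured so far:
Compound 1, `CNC(=O)c1c(-c2ccc(F)cc2)oc2ccc(-c3cccc(C(=O)NC4(c5ccccn5)CC4)c3)cc12`: 91%
Compound 2, `CNC(=O)c1c(-c2ccc(F)cc2)oc2cc(N(CCO)S(C)(=O)=O)c(-c3cccc(C(=O)NC4(c5ccccn5)CC4)c3)cc12`: 99%

In an ADME assay on microsomes from liver (Homo sapiens) for metabolic stability (a lower number here means that less of the compound is left, a higher number that more of the compound is left), compound 2 gives the higher of the two numbers, but the step of a number 8 percentage points higher from compound 1 to compound 2 (within the scatter) lies within the scatter, so the two compounds cannot be told apart. Compound 3, `CNC(=O)c1c(-c2ccc(F)cc2)oc2cc(N(CCO)S(C)(=O)=O)c(-c3cccc(C(=O)NC4(c5ccccc5)CC4)c3)cc12`, differs from compound 2 by phenyl in place of pyridin-2-yl on a saturated ring carbon. Going by the values given here, no measured step bears on this change; the only step known concerns a different position. With nothing to go on, a step beyond the scatter is not expected, and compound 3 is estimated to keep most of the compound, a number 6 percentage points lower from compound 2 to compound 3 (within the scatter), giving 93% with a range from 80% to 100%.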

Compound 3, percent of the compound remaining: 63%
Compound 3: the middle estimate sits 30 percentage points above what was measured; the measured number lies below the stated range.
By their numbers in this assay, from the lowest: compound 3; then compounds 1 and 2 (each within the scatter of the next).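

In this assay, the pyridin-2-yl on the three-membered ring proves to matter: phenyl in its place gives a number 36 percentage points lower from compound 2 to compound 3 (beyond the scatter). Going by these compounds alone, the only earlier step concerned a different position, so this is the first sign that this site is sensitive, and exchanging one ring nitrogen for carbon is enough to show it. Nothing measured here explains the drop. Going by these compounds, whether pyridin-3-yl or pyrimidin-2-yl on the same ring carbon would behave like pyridin-2-yl or like phenyl remains open. So does whether phenyl would have the same effect without the (2-hydroxyethyl)(methylsulfonyl)amino group.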